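A few compounds are considered here, and "the series" means these few. Any claim that something is new, unique, unknown or untested is made for them only; others in the source may bear on it.

Compound 1 `COc1cc(C(c2ccc(O)c(OC)c2)[C@H](C)[C@H](C)CF)ccc1O`: in a functional assay on HL-60 cells (Homo sapiens) for cytotoxicity, read by WST assay, with a stated time of 48 h (on this read-out higher numbers stand for weaker inhibition and lower numbers for stronger inhibition), compound 1 gives 56000 nM.
Compound 2 `COc1cc(C(c2ccc(O)c(OC)c2)[C@H](C)[C@@H](C)CF)ccc1O`: compound 2 gives 45000 nM.
Compound 3 `COc1cc(C(c2ccc(O)c(OC)c2)[C@H](C)[C@H](C)CO)ccc1O`: compound 3 gives > 100000 nM, which is a limit of the assay.

Of the two numbers, compound 1 stands highest; its nearest neighbour lies a 1.2-fold lower number from compound 1 to compound 2 (0.09 log units; within the scatter), the pair differing only in configuration as drawn (the fact that compounds 1 and 2 differ only in the configuration as drawn). The step of an at least 1.7-fold higher number from compound 1 to compound 3 (0.25 log units; that floor lies within the scatter) has its floor within the scatter; the step of an at least 2.2-fold higher number from compound 2 to compound 3 (0.34 log units; beyond the scatter) reaches beyond it, both ending at the limit (the limit of > 100000 nM in this assay, at which 1 of the 3 values shown sits).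

Compound 4 `COc1cc(C(c2ccc(O)c(OC)c2)[C@@H](C)C(C)C)ccc1O` carries 1,2-dimethylpropyl in place of 2-(fluoromethyl)-1-methylpropyl on a saturated chain carbon bound to two aromatic carbons. Among the measured compounds shown here, no measured step removes the fluoro outright; the nearest, compound 1 to compound 3, exchanged it for hydroxy. A step of about a 1.1-fold lower number from compound 1 to compound 4 (0.05 log units; within the scatter) is expected, with no direction beyond the scatter. For compound 4 the estimate in this assay is 50000 nM, range 20000 nM to 120000 nM.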

Compound 4, half-maximal inhibitory concentration: 20000 nM
The estimate for compound 4 lay 2.5-fold (0.40 log units) above the measured number; measured number inside the range.
By their numbers in this assay, from the lowest: compound 4; then compounds 2 and 1 (each within the scatter of the next). At a limit, above all of these: compound 3.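

In this assay the 1,2-dimethylpropyl group, on a saturated chain carbon bound to two aromatic carbons, gives lower numbers than the 2-(fluoromethyl)-1-methylpropyl group in both fluoro compounds (a 2.8-fold lower number from compound 1 to compound 4 (0.45 log units; beyond the scatter)) and (a 2.3-fold lower number from compound 2 to compound 4 (0.35 log units; beyond the scatter)), so the fluoro is not required at this position. Compound 3 gives > 100000 nM which is a limit of the assay and not a number. Against that limit the step to the 1,2-dimethylpropyl group is (an at least 5.0-fold lower number from compound 3 to compound 4 (0.69 log units; beyond the scatter)), in the same direction as the two fluoro steps.

From the compounds shown here alone, whether an amine, a carboxylic acid or a longer chain at this position would lower the number further remains open.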